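This account rests on a few compounds, and the source may have more. Where it says the series, first, only, none or still open, it means among the compounds named here.

Of the compounds shown here, two on a shared core have numbers so far in a functional assay on MCF7 cells (Homo sapiens) for antiproliferative activity, read by MTT assay, with a stated time of 72 h; on this read-out higher numbers stand for weaker inhibition and lower numbers for stronger inhibition. There, compound 1 (`CCc1ccccc1OS(=O)(=O)C1CC2OC1C(c1ccc(/C=C/c3cc(OC)cc(OC)c3)cc1)=C2c1ccc(O)cc1`) gives 49800 nM, while compound 2 (`O=S(=O)(Oc1ccc(Cl)cc1)C1CC2OC1C(c1ccc(/C=C/c3cc(O)cc(O)c3)cc1)=C2c1ccc(O)cc1`) gives 17900 nM, the lower of the two numbers and apart from the other by more than the usual scatter. These two compounds differ in more than one place, so their gap cannot be tied to any single group. Compound 3 (`O=S(=O)(Oc1cccc(C(F)(F)F)c1)C1CC2OC1C(c1ccc(/C=C/c3cc(O)cc(O)c3)cc1)=C2c1ccc(O)cc1`) keeps everything in compound 2 except one group: 3-(trifluoromethyl)phenyl in place of 4-chlorophenyl on an oxygen. Going by the values given here, no measured pair shows this kind of change, so the data give no direct guide to its size or direction. The estimated step of a 1.2-fold lower number from compound 2 to compound 3 (0.08 log units; within the scatter) in this assay is expected to stay within the scatter. The expected value for compound 3 is 15000 nM, with an estimated range from 6000 nM to 40000 nM.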

Compound 3, half-maximal inhibitory concentration: 11500 nM
The estimate for compound 3 lay 1.3-fold (0.12 log units) above the measured number; low and high end bracket the measured number.
By their numbers in this assay, from the lowest: compounds 3 and 2 (each within the scatter of the next); then compound 1.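

In this assay, placing 3-(trifluoromethyl)phenyl on the oxygen bonded to the sulfonyl sulfur, in place of 4-chlorophenyl, gives a 1.6-fold lower number from compound 2 to compound 3 (0.19 log units; within the scatter) on the shared core. Going by these compounds alone, this is the first pair that differs in one place, and it shows that these two substituted phenyl groups can be exchanged at this position without the number moving beyond the scatter. No measurement shown here offers an explanation for this result.

On these data alone, whether this tolerance extends to groups of another kind on that oxygen, such as a phenyl carrying an amine or a carboxylic acid, or a plain methyl, remains open. The compounds shown also leave open whether the same exchange would behave alike on the dimethoxy-bearing core of compound 1.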